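This account rests on a few compounds, and the source may have more. Where it says the series, first, only, none or still open, it means among the compounds named here.

Of the compounds shown here, three have been measured in an ADME assay on microsomes from liver (Homo sapiens) for metabolic stability, read by LC-MS, with a stated time of 30 min, tested at 1 uM; on this read-out higher numbers stand for a more stable compound and lower numbers for a less stable compound. Compound 1 `O=C(NCc1ccc(S(=O)(=O)c2ccccc2)cc1)c1nc2ccncc2s1` gives 68%, the second highest of the three numbers. Compound 3 `O=C(NCc1ccc(S(=O)(=O)c2cc(F)cc(F)c2)cc1)c1cc2cnccc2[nH]1` gives 82%, which is higher, and compound 2 `O=C(NCc1ccc(S(=O)(=O)N2CCCCC2)cc1)c1cc2ccncc2[nH]1` gives 50%, which is lower. Both gaps to compound 1 lie beyond the scatter.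

Compound 4 `O=C(NCc1ccc(S(=O)(=O)c2ccccc2)cc1)c1ccc2nncn2c1` has not yet been measured. It departs from compound 1 in one place, on a carbonyl carbon: a group of 9 heavy atoms (6 carbon, 3 nitrogen; one five-membered aromatic ring with 3 hetero atoms, one six-membered aromatic ring with 1 hetero atom) in place of a group of 9 heavy atoms (6 carbon, 2 nitrogen, 1 sulfur; one five-membered aromatic ring with 2 hetero atoms, one six-membered aromatic ring with 1 hetero atom), on a carbonyl carbon. The group that enters has the same ring sizes as the one that leaves, with a nitrogen counted in place of the sulfur.

For the measured compounds named here, no two measured compounds differ in one place only, so the data hold no direct precedent for this change. A small downward step is expected, one that would stay within the scatter, though the direction is uncertain. The estimate corresponds to a number 6 percentage points lower from compound 1 to compound 4 (within the scatter). The range is kept wide, as the measured compounds run from compound 2 at 50% to compound 3 at 82%. Compound 4 is expected to give 62%, within an estimated range from 42% to 80%.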

Compound 4, percent of the compound remaining: 96%
Beside the measured number, compound 4's estimate is 34 percentage points below it; the measured number lies above the stated range.
By their numbers in this assay, from the lowest: compound 2; then compound 1; then compound 3; then compound 4.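

In this assay, the group on the carbonyl carbon can move the number by itself: exchanging the group that holds sulfur for the one with a nitrogen counted in its place gives a number 28 percentage points higher from compound 1 to compound 4 (beyond the scatter). For the compounds shown here, this is the first step here that changes one place only, so the position can now be read apart from the rest of the molecule, which the earlier compounds, differing in more than one place, did not allow. The data shown offer no measured basis for explaining this step.

The compounds shown leave open whether the same exchange would give a step of this size in compounds that keep the other sulfonyl groups of compound 2 or compound 3. They also leave open whether a methyl group or an amine carried on the entering group would keep the number of compound 4.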